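Oxadiazole linker change: benzyl to anilino in an EP1 series

The compounds below may be only part of what the source reports. "The series", "measured", "known", "first", "only" and "open" are said of these compounds alone.

Measured compounds:
Compound 1 `CCOc1ccc(Cc2nnc(CN(c3ccccc3CC)S(=O)(=O)c3ccc(C)cc3)o2)cc1`: 39.8 nM
Compound 2 `COc1ccc(Cc2nnc(CN(c3cccc(Cl)c3Cl)S(=O)(=O)c3ccc(C)cc3)o2)cc1`: 39.8 nM
Compound 3 `Cc1ccc(S(=O)(=O)N(Cc2nnc(Cc3ccc(N(C)C)cc3)o2)c2cccc(Cl)c2C)cc1`: 20 nM

In a functional assay on CHO cells for antagonist activity at prostaglandin E2 receptor EP1 subtype (Homo sapiens), read by FLIPR and calcium flux (on this read-out higher numbers stand for weaker inhibition and lower numbers for stronger inhibition), compound 3 gives 20 nM, the lowest of the three numbers, yet both compound 1 and compound 2 sit within the usual scatter of it, so no order among the three can be read from these values. Compound 4 `COc1ccc(Nc2nnc(CN(c3cccc(Cl)c3C)S(=O)(=O)c3ccc(C)cc3)o2)cc1` has not been measured. It differs from compound 3 in one place: (4-methoxyphenyl)amino in place of 4-(dimethylamino)benzyl on an aromatic carbon. Among the measured compounds shown here, no measured pair shows this kind of change, so the size of the step is open. A modest move toward weaker inhibition is expected, a 3.2-fold higher number from compound 3 to compound 4 (0.50 log units; beyond the scatter), since the known values give no anchor for a linker of this kind. Compound 4 is therefore estimated at 63 nM, in the range 15 nM to 250 nM.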

Compound 4, inhibition constant: 79.4 nM
For compound 4 the middle estimate is 1.3-fold (0.10 log units) below the measured one; the range from low to high includes it.
By their numbers in this assay, from the lowest: compounds 3, 1, 2 and 4 (each within the scatter of the next, the first and the last beyond it).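

In this assay, among the compounds shown here, putting (4-methoxyphenyl)amino in place of 4-(dimethylamino)benzyl on this aromatic carbon gives a 4.0-fold higher number from compound 3 to compound 4 (0.60 log units; beyond the scatter), the first step that lies beyond the scatter. The position therefore responds to this exchange, in which the entering group carries a hydrogen-bond donor that the leaving group lacks. Nothing at hand accounts for the size of this step.

The exchange alters both the link to the ring and the group on that ring, and the compounds shown do not separate the two. A (4-(dimethylamino)phenyl)amino group at this position would bear on that question.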